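From ethoxy to methylsulfanyl

A few compounds are considered here, and "the series" means these few. Any claim that something is new, unique, unknown or untested is made for them only; others in the source may bear on it.

Of the compounds shown here, two have numbers so far in an ADME assay on a cell-free system (plasma, Homo sapiens) for protein binding. Compound 1 `Cc1cc(Nc2ccc(S(F)(F)(F)(F)F)cc2)n2nc(C3CC3)nc2n1` gives 97.7%, and compound 2 `CCOc1nc2nc(C)cc(Nc3ccc(C(F)(F)F)cc3)n2n1` gives 92.4%. Both are mostly bound, and what counts on this scale is the small free remainder. Compound 2 has the larger free share of the two, and the gap between the two compounds lies beyond the usual scatter.

The next compound, compound 3 `CSc1nc2nc(C)cc(Nc3ccc(C(F)(F)F)cc3)n2n1`, keeps the core of compound 2 and changes one group: methylsulfanyl in place of ethoxy on an aromatic carbon. Going by the values given here, no measured pair shows this swap on its own, and compound 1 differs from compound 2 in more than one place, which leaves no direct guide to its size. The expected change is small: the estimated step a 1.1-fold lower unbound fraction from compound 2 to compound 3 (0.04 log units; within the scatter) should stay within the usual scatter, with no firm direction. The value of compound 2 is therefore the best anchor available. For compound 3 the expected value in this assay is 93%, with an estimated range from 87% to 96.5%.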

Compound 3, plasma protein binding: 91.8%
Compound 3: the middle estimate sits 1.2-fold (0.07 log units) (unbound fraction) below what was measured; the measured number falls inside the stated range.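

Going by these compounds alone, the exchange of ethoxy for methylsulfanyl, on an aromatic carbon between two ring nitrogen atoms, amounts to a 1.1-fold higher unbound fraction from compound 2 to compound 3 (0.03 log units; within the scatter) and gives the first comparison here of compounds that differ in one place, since compound 1 differs from compound 2 in more than one. The entering group has one heavy atom fewer and carries sulfur where the leaving group carries oxygen, yet in this assay these two compounds cannot be told apart, so on this core the two groups are interchangeable as far as this read-out goes. No measurement at hand accounts for this result.

A single pair, with two groups that have the same count of hydrogen-bond acceptors and no net charge, leaves open what happens in this assay when something quite different sits at this position, such as an amine, a carboxylic acid or a longer chain like butoxy. It also leaves open whether the same exchange would read the same way on another core, such as the core of compound 1, where the free share is smaller.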